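Working notes: amide group change from compound 2 to compound 3

A few compounds are considered here, and "the series" means these few. Any claim that something is new, unique, unknown or untested is made for them only; others in the source may bear on it.

- compound 1 `CNC(=O)c1cc(C(=O)N[C@H]2[C@@H]3COC[C@@H]32)cc2c1OC[C@H]2c1ccccc1` gives 3.3
- compound 2 `CNC(=O)c1cc(C(=O)Nc2cnn(C)c2)cc2c1OC[C@H]2c1ccccc1` gives 3.5

Both numbers come from a physicochemical assay for lipophilicity, at pH 7.4; on this read-out lower numbers stand for lower lipophilicity and higher numbers for higher lipophilicity. Compound 2 stands at 3.5, and compound 1 lies within the scatter of it at 3.3. The next compound to be measured is compound 3 `CNC(=O)c1cc(C(=O)NCCC[C@H]2OC[C@H](N)CO2)cc2c1OC[C@H]2c1ccccc1`. It loses the 1-methyl-1H-pyrazol-4-yl group of compound 2, and the change reads (a group of 10 heavy atoms (7 carbon, 1 nitrogen, 2 oxygen; one six-membered non-aromatic ring with 2 hetero atoms) in place of a group of 6 heavy atoms (4 carbon, 2 nitrogen; one five-membered aromatic ring with 2 hetero atoms), on an amide-type nitrogen).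

Among the measured compounds shown here, only one measured step bears on this change. It also exchanges a group on an amide-type nitrogen, and it amounts to a number 0.20 log units higher from compound 1 to compound 2 (within the scatter). That small step is weak guidance, as neither group in it resembles the group entering compound 3. For the measured compounds named here, no measured compound carries a six-membered non-aromatic ring with 2 hetero atoms, so the direction and size of the new step remain a judgement from the structural change alone.

In this assay a fall beyond the scatter is expected, and the estimated change is a number 1.10 log units lower from compound 2 to compound 3 (beyond the scatter). For compound 3 the estimated value is 2.4, with an expected range from 1.7 to 3.1.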

Compound 3, distribution coefficient: 2.6
For compound 3 the middle estimate is 0.20 log units below the measured one, within the range that was stated.
By their numbers in this assay, from the lowest: compound 3; then compounds 1 and 2 (each within the scatter of the next).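

In this assay the group on the amide-type nitrogen now proves able to shift the read-out: the earlier exchange gave only a small step (a number 0.20 log units higher from compound 1 to compound 2 (within the scatter)), whereas the group entering compound 3 gives a clear one (a number 0.90 log units lower from compound 2 to compound 3 (beyond the scatter)). The fall holds against both earlier amide groups, the 1-methyl-1H-pyrazol-4-yl group and the group of compound 1 with its three-membered and five-membered rings, as the second new step shows (a number 0.70 log units lower from compound 1 to compound 3 (beyond the scatter)). Nothing measured here accounts for the fall, so the step stands as an observation without an assigned origin.

The entering group brings its chain, its six-membered non-aromatic ring with 2 hetero atoms and its amine in one exchange, so the share of each in the step cannot be read from these three compounds. On these data alone, how this assay would respond to a shorter chain on the amide-type nitrogen, to the same ring without the amine, or to a carboxylic acid in place of the amine stays open.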